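A few compounds are considered here, and "the series" means these few. Any claim that something is new, unique, unknown or untested is made for them only; others in the source may bear on it.

Compound 1 `Cc1cc(-c2nc3sc(C)cn3c2/C=N/NC(=N)N)c(C)s1`: 14100 nM
Compound 2 `Cc1cn2c(/C=N/NC(=N)N)c(-c3ccsc3)nc2s1`: 10200 nM
Compound 3 `N=C(N)N/N=C/c1c(-c2cccs2)nc2sccn12`: 8320 nM

All three values come from a functional assay on cells (Cancer cell lines, Homo sapiens) for inhibition; on this read-out lower numbers stand for stronger inhibition of growth and higher numbers for weaker inhibition of growth. Compound 3, at 8320 nM, stands within the scatter of both other compounds, so the three form a single group on these numbers and no order can be drawn among them.

The next compound is compound 4 `Cc1cn2c(/C=N/NC(=N)N)c(-c3cccs3)nc2s1`, which is to be measured in this assay. Its structure differs from that of compound 3 by methyl in place of hydrogen on an aromatic carbon, in the five-membered aromatic ring with 1 nitrogen and 1 sulfur.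

For the measured compounds named here, only one step has been measured between compounds differing in one place: a 1.4-fold lower number from compound 1 to compound 2 (0.14 log units; within the scatter). It stays within the scatter, but it concerns thiophen-3-yl in place of 2,5-dimethylthiophen-3-yl, so it bears on the new change only indirectly. Going by the values given here, no measured step isolates methyl in place of hydrogen at the new site. Among the compounds with values here, the narrow spread of the three values and the small size of the one measured step give no ground for expecting a change beyond the scatter.

The expected 1.1-fold higher number from compound 3 to compound 4 (0.06 log units; within the scatter) is therefore no real shift in either direction.

For compound 4 the estimated value is 9500 nM, with an expected range of 5000 nM to 18000 nM.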

Compound 4, concentration for 50% growth inhibition: 4270 nM
For compound 4 the middle estimate is 2.2-fold (0.35 log units) above the measured one; measured number below the stated range.
By their numbers in this assay, from the lowest: compounds 4, 3, 2 and 1 (each within the scatter of the next, the first and the last beyond it).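

In this assay, for the compounds shown here, methyl in place of hydrogen on the aromatic carbon next to the ring sulfur gives a 1.9-fold lower number from compound 3 to compound 4 (0.29 log units; within the scatter) and so gives the first direct reading at this site, where the group's entry leaves the step within the scatter. With this methyl present in all three compounds, the thiophene group now separates them: thiophen-2-yl in place of thiophen-3-yl gives a 2.4-fold lower number from compound 2 to compound 4 (0.38 log units; beyond the scatter) and thiophen-2-yl in place of 2,5-dimethylthiophen-3-yl gives a 3.3-fold lower number from compound 1 to compound 4 (0.52 log units; beyond the scatter) as modest steps beyond the scatter, whereas a 1.4-fold lower number from compound 1 to compound 2 (0.14 log units; within the scatter) alone showed nothing beyond it. No measurement is at hand that would explain any of these steps.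

Open, as far as these compounds go, is whether methyl in place of hydrogen at this carbon gives a similar step when thiophen-3-yl replaces thiophen-2-yl, as no hydrogen-bearing partner of compound 2 stands in this set. Also open, from the compounds shown here alone, is whether an ethyl chain, an amine or a carboxylic acid on the same carbon, or a phenyl ring in place of the thiophene, would take the number beyond the scatter.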